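From Methyl to Trifluoromethyl on an Aromatic Carbon

The compounds below may be only part of what the source reports. "The series", "measured", "known", "first", "only" and "open" are said of these compounds alone.

Three compounds built on one shared core have numbers in a functional assay on SK-LU-1 cells (Homo sapiens) for cytotoxicity, read by sulforhodamine B assay, with a stated time of 48 h; on this read-out lower numbers stand for stronger inhibition and higher numbers for weaker inhibition. Compound 1 `O=C(c1ccc(C(F)(F)F)c(F)c1)c1ccc2nc(NC(=O)C(F)(F)F)cn2c1` gives 53000 nM. Compound 2 `Cc1ccc(F)c(C(=O)c2ccc3nc(NC(=O)C(F)(F)F)cn3c2)c1` gives 57100 nM, and compound 3 `Cn1cc(C(=O)c2ccc3nc(NC(=O)C(F)(F)F)cn3c2)c2ccccc21` gives 24800 nM. Compound 2 and compound 1 therefore sit level within the usual scatter of repeated measurements, while compound 3 has a lower number than compound 2, by a margin just beyond that scatter.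

Compound 4 `O=C(c1ccc2nc(NC(=O)C(F)(F)F)cn2c1)c1cc(C(F)(F)F)ccc1F` follows from compound 2 with trifluoromethyl in place of methyl on an aromatic carbon. Within the data shown here, no measured pair differs by this change alone, so the evidence is indirect. Compound 1, which also carries a trifluoromethyl group, gives 53000 nM, level with compound 2. In this assay, no change beyond the scatter is therefore expected. The estimated size of the step is small, a 1.1-fold lower number from compound 2 to compound 4 (0.06 log units; within the scatter). For compound 4 the estimated value is 50000 nM, with an expected range of 22000 nM to 110000 nM.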

Compound 4, half-maximal inhibitory concentration: 11200 nM
Beside the measured number, compound 4's estimate is 4.5-fold (0.65 log units) above it; measured number outside the range, below it.
By their numbers in this assay, from the lowest: compound 4; then compound 3; then compounds 1 and 2 (each within the scatter of the next).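

Replacing methyl with trifluoromethyl on this aromatic carbon, para to a fluoro group, gives a 5.1-fold lower number from compound 2 to compound 4 (0.71 log units; beyond the scatter) in this assay and so moves the compound towards stronger inhibition. This is the only pair shown that differs in one place, so it gives the first direct sign that the group on this carbon matters, which the earlier compounds could show only indirectly. Nothing among the data shown accounts for the size of this step.

From the compounds shown here alone, it remains open whether other groups on this carbon, such as a chlorine atom, a methoxy group or an amine, would lower the number further or lose the gain. Going by these compounds, whether the same swap gives a similar step on a different core or in another cell line also stays open.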